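This account rests on a few compounds, and the source may have more. Where it says the series, first, only, none or still open, it means among the compounds named here.

Measured compounds: compound 2 `Cc1cc(NCc2ccc(OCc3c(-c4c(Cl)cccc4Cl)noc3C(C)C)cc2)ccc1CC(=O)O` with 1200 nM in an assay on HEK-293T cells for activation of Bile acid receptor (Homo sapiens), read by a luciferase reporter, with a stated time of 14 h; on this read-out higher numbers stand for an effect only at larger amounts of compound and lower numbers for an effect already at smaller amounts; compound 1 `CC(C)c1onc(-c2c(Cl)cccc2Cl)c1COc1ccc(CNc2ccc(CC(=O)O)cc2)cc1` with 1600 nM.

Among the measured compounds shown here, compound 2 stands at the lower of the two numbers, but its only neighbour is compound 1, and the step of a 1.3-fold lower number from compound 1 to compound 2 (0.12 log units; within the scatter) leaves the two indistinguishable. Compound 3 `CC(C)c1onc(-c2c(Cl)cccc2Cl)c1COc1ccc(COc2ccc(CC(=O)O)cc2)cc1` is not yet measured. It differs from compound 2 by 4-(carboxymethyl)phenoxy in place of (4-(carboxymethyl)-3-methylphenyl)amino on a saturated chain carbon bound to an aromatic carbon. For the measured compounds named here, this step removes the methyl whose addition gave a 1.3-fold lower number from compound 1 to compound 2 (0.12 log units; within the scatter) and at the same time exchanges the linking nitrogen for oxygen; no measured pair shows the latter exchange, so only the methyl part has any precedent, and that part was without effect. The working expectation is therefore a step in this assay of no clear size, a 1.3-fold higher number from compound 2 to compound 3 (0.10 log units; within the scatter), in either direction. For compound 3 the estimate is 1500 nM, with a range of 500 nM to 5000 nM.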

Compound 3, half-maximal effective concentration: 2000 nM
Compound 3: middle estimate off by 1.3-fold (0.12 log units), on the low side, and the stated range covers the measured number.
By their numbers in this assay, from the lowest: compounds 2, 1 and 3 (each within the scatter of the next).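

In this assay, among the compounds shown here, 4-(carboxymethyl)phenoxy in place of (4-(carboxymethyl)phenyl)amino on a saturated chain carbon bound to an aromatic carbon gives a 1.3-fold higher number from compound 1 to compound 3 (0.10 log units; within the scatter) and is the one clean exchange of the linking nitrogen for oxygen, so this exchange is tolerated here without a step beyond the scatter. The exchange that also removes the methyl gives a 1.7-fold higher number from compound 2 to compound 3 (0.22 log units; within the scatter), which is likewise within the scatter, so neither the linking atom nor the methyl has yet been seen to move the number in this series. No data bearing on the reason for these results are available.

A methylene, a sulfur atom or an amide in the linking place could still separate from these three compounds. Also open, going by these compounds, is whether the carboxylic acid itself can be exchanged, for instance for a tetrazole or a primary amide.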